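Carbamoyl in place of 2-hydroxyethyl on the shared core

This account rests on a few compounds, and the source may have more. Where it says the series, first, only, none or still open, it means among the compounds named here.

Compound 1 (`C=CCOn1c(-c2cccc(C#N)c2)nc(C)c1C(=O)OCC`) gives 5860 nM
Compound 2 (`CCOC(=O)c1c(C)nc(-c2cccc(C#N)c2)n1OCCCO`) gives 11400 nM

In a functional assay on a cell-free system (plasma, Oryctolagus cuniculus) for inhibition, with stated times of 5 min, 1 min and 6 min (a lower number here means a stronger inhibitor, a higher number a weaker inhibitor), compound 2 gives 11400 nM and stands level with compound 1 once the usual scatter is allowed for. Compound 3 (`CCOC(=O)c1c(C)nc(-c2cccc(C#N)c2)n1OCC(N)=O`) has not yet been measured. It carries carbamoyl in place of 2-hydroxyethyl on a saturated chain carbon bound to an oxygen on an aromatic ring. Among the compounds with values here, only one measured step bears on this place, the one that put 2-hydroxyethyl in place of vinyl (a 1.9-fold higher number from compound 1 to compound 2 (0.29 log units; within the scatter)). Carbamoyl itself has not been tested here, so this step is only a loose guide. Within the data shown here, with that step as the sole evidence, no change beyond the scatter is expected in this assay and no direction is favoured. The estimated step is small (a 1.1-fold lower number from compound 2 to compound 3 (0.06 log units; within the scatter)). For compound 3 the estimate is 10000 nM with 4000 nM to 25000 nM as the expected range.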

Compound 3, half-maximal inhibitory concentration: > 30000 nM
Compound 3 gave a limit, no number; the forecaster's own chance of this, stated with the estimate: 10%; middle value at least 3.0-fold (0.47 log units) away from the limit.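

In this assay, this position turns out to respond to the group placed on it, which the earlier change from vinyl to 2-hydroxyethyl, within the scatter, did not show: carbamoyl in place of 2-hydroxyethyl gives an at least 2.6-fold higher number from compound 2 to compound 3 (0.42 log units; beyond the scatter). Carbamoyl in place of vinyl gives an at least 5.1-fold higher number from compound 1 to compound 3 (0.70 log units; beyond the scatter), and this weakening appears even though 2-hydroxyethyl and carbamoyl match in their counted heavy atoms, hydrogen-bond donors and hydrogen-bond acceptors, so those counts alone do not separate them. Compound 3 gives a limit, not a number: the limit of > 30000 nM in this assay, at which 1 of the 3 values shown sits.

The compounds shown leave open whether the weakening belongs to carbamoyl alone or would also follow from a carboxylic acid or an amine at this place. They also leave open how a longer chain ending in carbamoyl would behave.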